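Phenyl in place of benzyl on an amide-type nitrogen

The source may report more compounds than this note shows. Statements on the series, on what has been measured and on what is new or still open speak of the compounds shown alone.

Of the compounds shown here, two have been measured so far in an ADME assay on HepG2 cells (Homo sapiens), read by MTT assay, with a stated time of 72 h, in the presence of a further agent that is not named here; a higher number here means a weaker inhibitor, a lower number a stronger inhibitor. Compound 1 `O=C(Nc1ccccc1)Oc1ccc(Cl)cc1C(=O)Nc1ccc(Cl)cc1` gives 900 nM, and compound 2 `O=C(NCc1ccccc1)Oc1ccc(Cl)cc1C(=O)Nc1ccc(C(F)(F)F)cc1` gives 3000 nM. Compound 2 thus has the higher of the two numbers, a gap beyond the scatter that marks it as the weaker inhibitor. These two compounds differ in more than one place, so their gap cannot be assigned to a single change. Compound 3 `O=C(Nc1ccccc1)Oc1ccc(Cl)cc1C(=O)Nc1ccc(C(F)(F)F)cc1` has phenyl in place of benzyl on an amide-type nitrogen of compound 2: phenyl in place of benzyl on an amide-type nitrogen. For the measured compounds named here, no measured pair isolates this change, but compound 1 also carries phenyl there and reads 900 nM. A moderate fall in the number is expected in this assay. The expected step is a 2.3-fold lower number from compound 2 to compound 3 (0.36 log units; beyond the scatter). Compound 3 is estimated at 1300 nM, with an expected range of 500 nM to 3200 nM.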

Compound 3, half-maximal inhibitory concentration: 2450 nM
Beside the measured number, compound 3's estimate is 1.9-fold (0.28 log units) below it; low and high end bracket the measured number.
By their numbers in this assay, from the lowest: compound 1; then compounds 3 and 2 (each within the scatter of the next).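

In this assay, a 1.2-fold lower number from compound 2 to compound 3 (0.09 log units; within the scatter) lies within the scatter, so with trifluoromethyl held in both compounds, this assay does not separate phenyl from benzyl on the amide-type nitrogen. The change on the aromatic carbon can now be read on its own, and a 2.7-fold higher number from compound 1 to compound 3 (0.43 log units; beyond the scatter) is modest but beyond the scatter, making it the only one of the two single changes shown to clear the scatter. No measurement is at hand that bears on what lies behind either step.

From the compounds shown here alone, each change is read only once, on a single background, so it remains open whether phenyl and benzyl also read alike with chloro on the aromatic carbon. Also open, going by these compounds, is how a nitrile or methoxy group on that carbon, or a longer chain such as phenethyl on the nitrogen, would read.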